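Methyl in Place of Hydrogen on the Ring Amine

The source may hold more compounds than are shown below. What is called first, only, known or untested is meant among the compounds shown, and "the series" means these compounds.

Compound 1 `CCCCNc1nc(N)nc2c1CN(Cc1ccccc1)CC2`: 0.06 uM
Compound 2 `CCCCNc1nc(N)nc2c1CCN(Cc1ccccc1)C2`: 0.4 uM
Compound 3 `CCCCNc1nc(N)nc2c1CNCC2`: 7.2 uM

In an assay on HEK293 cells for agonist activity at Toll-like receptor 8 (Homo sapiens), read by a luciferase reporter, with a stated time of 6 h (on this read-out lower numbers stand for an effect already at smaller amounts and higher numbers for an effect only at larger amounts of compound), compound 3 stands highest of the three numbers; compound 2 is nearest and compound 1 furthest, both with lower numbers beyond the scatter. Compound 4 `CCCCNc1nc(N)nc2c1CN(C)CC2` differs from compound 3 in one place: methyl in place of hydrogen on an amine nitrogen in a ring. For the measured compounds named here, the one measured step that bears on this position is a 120-fold higher number from compound 1 to compound 3 (2.08 log units; beyond the scatter), where a substituent left the same ring amine nitrogen and the number rose sharply. A methyl puts a substituent back at that nitrogen, though a far smaller one than benzyl, so a lower number than compound 3 is expected, with a step well short of that benzyl step. Compound 4 is therefore estimated at 2 uM, in a range from 0.5 uM to 7 uM, which corresponds to an expected step of a 3.6-fold lower number from compound 3 to compound 4 (0.56 log units; beyond the scatter).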

Compound 4, minimum effective concentration: 0.03 uM
Compound 4: the middle estimate sits 67-fold (1.82 log units) above what was measured, and the stated range ends above it.
By their numbers in this assay, from the lowest: compounds 4 and 1 (each within the scatter of the next); then compound 2; then compound 3.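

In this assay, methyl in place of hydrogen on the ring amine nitrogen gives a 240-fold lower number from compound 3 to compound 4 (2.38 log units; beyond the scatter) on its own, so the smallest substituent among these compounds is enough for a large change at this position. The earlier benzyl step did not show this. Benzyl and methyl cannot be told apart here: a 2.0-fold lower number from compound 1 to compound 4 (0.30 log units; within the scatter) lies within the scatter, so the phenyl of the benzyl group is not required for a low number. As far as these compounds go, whether ethyl or a longer chain on this nitrogen would hold that low number stays open. No measurement at hand explains the effect of the methyl.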